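Cytotoxicity of a Butylamino Analogue, Before Measurement

A few compounds are considered here, and "the series" means these few. Any claim that something is new, unique, unknown or untested is made for them only; others in the source may bear on it.

Compound 1 `O=c1n(Cc2nc3cc(Cl)ccn3c2CO)c2cnccc2n1C1CC1`: in an ADME assay on HEp-2 cells (Homo sapiens) for cytotoxicity, read by CCK-8 assay, with a stated time of 6 days (a higher number here means that more compound is tolerated, a lower number that less compound is tolerated), compound 1 gives > 100000 nM, which is a limit of the assay and not a number.
Compound 2 `O=C(CCc1c(Cn2c(=O)n(C3CC3)c3ccncc32)nc2cc(Cl)ccn12)NCCO`: in this assay compound 2 gives > 100000 nM, again a limit.
Compound 3 `CS(=O)(=O)CCc1c(Cn2c(=O)n(C3CC3)c3ccncc32)nc2cc(Cl)ccn12`: in this assay compound 3 gives > 100000 nM, likewise a limit.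

Compound 3 therefore stands nowhere on a scale of numbers: it sits at the limit, and so do the two other measured compounds, as the limit of > 100000 nM in this assay, at which 3 of the 3 values shown sit, records. For the measured compounds named here, none of the measured steps can be read in size: a step that the two limits leave unreadable from compound 1 to compound 3, a step that the two limits leave unreadable from compound 2 to compound 3 and a step that the two limits leave unreadable from compound 1 to compound 2 all run between limits.

The unmeasured compound 4 `CCCCNc1c(Cn2c(=O)n(C3CC3)c3ccncc32)nc2cc(Cl)ccn12` differs from compound 3 in one place: butylamino in place of 2-(methylsulfonyl)ethyl on an aromatic carbon. Going by the values given here, the steps that bear on this change, those into compound 3 from compound 1 and compound 2, were both unreadable, so nothing in the measured series argues for a step of any size in this assay in either direction.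

The expectation for compound 4 is accordingly that this assay will again report a limit, so that the step of a number no higher from compound 3 to compound 4 (the limit leaves the size open) is estimated to be none beyond the scatter. Compound 4 is thus estimated at 100000 nM, with a range from 40000 nM to 250000 nM.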

Compound 4, half-maximal cytotoxic concentration: > 100000 nM
Compound 4 was reported as a limit (the forecaster's own chance of this, stated with the estimate: 80%); the middle value sits exactly at the limit.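

In this assay compound 4 gives > 100000 nM, which is a limit of the assay and not a number. The steps into compound 4 from compound 1, compound 2 and compound 3 therefore cannot be read, and the series ends as a whole at one limit: the limit of > 100000 nM in this assay, at which 4 of the 4 values shown sit.

The compounds shown leave open whether any group on this aromatic carbon would give a readable value, and how far the four compounds differ.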